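Trimming the Amide Ring of a Cathepsin S Inhibitor

This account rests on a few compounds, and the source may have more. Where it says the series, first, only, none or still open, it means among the compounds named here.

Three compounds have been measured in an assay on isolated protein for inhibition of cathepsin S (Homo sapiens), read by fluorescence, with a stated time of 20 min; a higher number here means a weaker inhibitor, a lower number a stronger inhibitor:

Compound 1, `N#CCNC(=O)[C@@H]1CC(F)(F)C[C@H]1C(=O)N1CCOCC1`, gives 830 nM
Compound 2, `CC(C)(C#N)NC(=O)[C@@H]1C[C@@H](S(=O)(=O)c2ccccc2)C[C@H]1C(=O)N1CCOCC1`, gives 3 nM
Compound 3, `N#CC1(NC(=O)[C@@H]2C[C@@H](S(=O)(=O)c3ccccc3)C[C@H]2C(=O)N2CC3CCC(C2)O3)CC1`, gives 1 nM

Among these three, compound 3 gives the lowest number in this assay. Its nearest neighbour is compound 2, and the gap between the two lies beyond the usual scatter, so compound 3 counts as the strongest inhibitor of the set; compound 1 lies far away from both.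

Compound 4, `N#CC1(NC(=O)[C@@H]2C[C@@H](S(=O)(=O)c3ccccc3)C[C@H]2C(=O)N2CCCC2)CC1`, has not yet been measured. Compared with compound 3 it carries a group of 5 heavy atoms (4 carbon, 1 nitrogen; one five-membered non-aromatic ring with 1 hetero atom) in place of a group of 8 heavy atoms (6 carbon, 1 nitrogen, 1 oxygen; one five-membered non-aromatic ring with 1 hetero atom, one six-membered non-aromatic ring with 2 hetero atoms), on a carbonyl carbon. Compounds 2 and 3 differ from each other in more than one place, so no single change among the measured compounds isolates the effect of the group on this carbonyl carbon. Both of those compounds, however, stay at very low numbers while carrying different groups there. For compound 4 a small rise in this assay is expected, with the step of a 3.0-fold higher number from compound 3 to compound 4 (0.48 log units; beyond the scatter) most likely only a little beyond the scatter. The estimate for compound 4 is 3 nM, within a range from 1 nM to 10 nM.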

Compound 4, half-maximal inhibitory concentration: 2 nM
For compound 4 the middle estimate is 1.5-fold (0.18 log units) above the measured one, and the stated range covers the measured number.
By their numbers in this assay, from the lowest: compounds 3, 4 and 2 (each within the scatter of the next, the first and the last beyond it); then compound 1.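

Within the data shown here, replacing the larger two-ring group on this carbonyl carbon with pyrrolidin-1-yl is the first single change at this place that can be read on its own, and in this assay the step is a 2.0-fold higher number from compound 3 to compound 4 (0.30 log units; within the scatter) and so gives no real difference between the two compounds. With the shared core held fixed, the oxygen and the second ring of the larger group are therefore not needed to keep the number this low, and the simple pyrrolidin-1-yl serves as well. No measurement at hand speaks to why these two groups behave alike.

As far as these compounds go, whether a smaller azetidin-1-yl or an open-chain dimethylamino group on this carbonyl carbon would also hold such low numbers remains open. So does whether pyrrolidin-1-yl would behave the same way on the core of compound 1.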